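Methyl added to the sulfonamide heterocycle of compound 2

This account rests on a few compounds, and the source may have more. Where it says the series, first, only, none or still open, it means among the compounds named here.

In a functional assay on HepG2 cells (Homo sapiens) for antiproliferative activity, read by sulforhodamine B assay, with a stated time of 48 h (on this read-out higher numbers stand for weaker inhibition and lower numbers for stronger inhibition), compound 2 `O=S(=O)(Nc1ncccn1)c1ccc(N/C(S)=N\c2ccnc3cc(C(F)(F)F)ccc23)cc1` gives 42100 nM, the numerically higher of the two numbers shown, though the gap to compound 1 is within the scatter. Compound 1 `Cc1noc(NS(=O)(=O)c2ccc(N/C(S)=N\c3ccnc4cc(C(F)(F)F)ccc34)cc2)c1C` gives 36800 nM, and the step of a 1.1-fold higher number from compound 1 to compound 2 (0.06 log units; within the scatter) records that. Compound 3 `Cc1ccnc(NS(=O)(=O)c2ccc(N/C(S)=N\c3ccnc4cc(C(F)(F)F)ccc34)cc2)n1` differs from compound 2 by methyl in place of hydrogen on an aromatic carbon. For the measured compounds named here, the only measured step, the heterocycle swap from compound 1 to compound 2, moved nothing beyond the scatter, and a methyl on that heterocycle gives no ground to expect more. Compound 3 is therefore estimated at 40000 nM, range 20000 nM to 80000 nM. The expected step of a 1.1-fold lower number from compound 2 to compound 3 (0.02 log units; within the scatter) lies within the scatter.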

Compound 3, half-maximal inhibitory concentration: "not active" (no number reported)
The entry for compound 3 holds no number, and the estimate cannot be compared.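

For the compounds shown here, compound 3 is entered as "not active" with no number, so no step from compound 2 to compound 3 can be read. On these data alone, whether 4-methylpyrimidin-2-yl shifts the read-out beyond the scatter stays open. No measured property bears on this result.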